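The source may hold more compounds than are shown below. What is called first, only, known or untested is meant among the compounds shown, and "the series" means these compounds.

Compound 1 `CC(=O)c1cc(-c2ccccc2)cc2cc(-c3ccc(F)cc3)[nH]c12` gives in a functional assay on MCF7 cells (Homo sapiens) for cytotoxicity, read by MTT assay, with a stated time of 2 days; on this read-out higher numbers stand for lower toxicity in this test and lower numbers for higher toxicity in this test > 100000 nM, a limit of the assay.
Compound 2 `COc1ccc(-c2cc3cc(-c4ccccc4)cc(C(C)=O)c3[nH]2)cc1` gives in this assay > 100000 nM, again a limit.

Compound 2 therefore stands at the limit of > 100000 nM in this assay, at which 2 of the 2 values shown sit, and has no number. Among the compounds with values here, the one measured step, a step that the two limits leave unreadable from compound 1 to compound 2, is unreadable. Compound 3 `COc1ccc(-c2cc3cc(/C=C/c4ccc(F)cc4)cc(C(C)=O)c3[nH]2)cc1` differs from compound 2 by 2-(4-fluorophenyl)ethenyl in place of phenyl on an aromatic carbon. Within the data shown here, no measured step bears on this change, so the size of the step in this assay is unknown. Compound 3 is expected at 100000 nM, within 30000 nM to 300000 nM. The expected step is a number no higher from compound 2 to compound 3 (the limit leaves the size open), most likely again only a limit.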

Compound 3, concentration lethal to 50% of the cells: 83000 nM
Compound 3: the middle estimate sits 1.2-fold (0.08 log units) above what was measured; low and high end bracket the measured number.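

With 2-(4-fluorophenyl)ethenyl in place of phenyl on this aromatic carbon, this assay gives a measured number for the first time in the compounds shown, with an at least 1.2-fold lower number from compound 2 to compound 3 (0.08 log units; that floor lies within the scatter). This position therefore tolerates the larger group, and compound 3 gives a number rather than a limit. The true size of the step stays open because compound 2 has only a limit: the limit of > 100000 nM in this assay, at which 2 of the 3 values shown sit.

Whether the ethenyl link or the fluoro group accounts for the number remains open. So does the outcome with an amine or a longer chain at this position.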